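Swapping the Group on the Amide Nitrogen of Compound 2

The source may hold more compounds than are shown below. What is called first, only, known or untested is meant among the compounds shown, and "the series" means these compounds.

For the measured compounds named here, compound 2 `COc1ccc2c(=O)c(/C=C/C(=O)NCc3ccccc3F)coc2c1` gives 8450 nM in a functional assay on Huh-7 cells (Homo sapiens) for inhibition, read by MTT assay, with a stated time of 48 h (on this read-out higher numbers stand for weaker inhibition and lower numbers for stronger inhibition), the lowest of the two numbers measured so far, with compound 1 `COc1cccc(NC(=O)/C=C/c2coc3cc(OC)ccc3c2=O)c1` nearest at 11100 nM. Compound 3 `COc1ccc2c(=O)c(/C=C/C(=O)Nc3ccccc3C)coc2c1` has not yet been measured; it differs from compound 2 by 2-methylphenyl in place of 2-fluorobenzyl on an amide-type nitrogen. Going by the values given here, only one measured step bears on this change: a 1.3-fold lower number from compound 1 to compound 2 (0.12 log units; within the scatter), which also exchanged the group on the amide-type nitrogen and stayed within the scatter. Compound 3 is therefore expected to show no step beyond the scatter, a 1.2-fold higher number from compound 2 to compound 3 (0.07 log units; within the scatter). The estimate for compound 3 is 10000 nM, within a range from 4000 nM to 25000 nM.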

Compound 3, half-maximal inhibitory concentration: 26900 nM
Compound 3: middle estimate off by 2.7-fold (0.43 log units), on the low side; measured number outside the range, above it.
By their numbers in this assay, from the lowest: compounds 2 and 1 (each within the scatter of the next); then compound 3.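

In this assay, the group on the amide-type nitrogen now gives steps beyond the scatter: 2-methylphenyl in place of 2-fluorobenzyl gives a 3.2-fold higher number from compound 2 to compound 3 (0.50 log units; beyond the scatter) and 2-methylphenyl in place of 3-methoxyphenyl gives a 2.4-fold higher number from compound 1 to compound 3 (0.38 log units; beyond the scatter). The earlier exchange at this nitrogen stayed within the scatter, so the number here does respond to some choices of group. No measurement at hand accounts for this difference. The compounds shown leave open which part of the 2-fluorobenzyl group matters, since the whole group changes in the step to compound 3. They also leave open how an amine on the phenyl ring or a longer chain such as 2-phenylethyl would read here.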